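Removing the Methoxyphenyl Arm: What Compound 3 Might Dissolve

This account rests on a few compounds, and the source may have more. Where it says the series, first, only, none or still open, it means among the compounds named here.

Compound 2 `COc1ccc(CNc2cc(CN3C(=O)N(c4ccc(SC(F)(F)F)cc4)C(=O)C3(C)C)ccn2)cc1` was tested in a physicochemical assay for solubility, read by nephelometry; a lower number here means a less soluble compound, a higher number a more soluble compound. For compound 2 this assay returned only a limit, < 0.027 ug/mL. Its close relative compound 1 `CC1(C)C(=O)N(c2ccc(SC(F)(F)F)cc2)C(=O)N1Cc1ccnc(N2CCNCC2)c1` also gave only a limit in this assay, < 0.024 ug/mL. Among the compounds with values here, the step that the two limits leave unreadable from compound 1 to compound 2 is unreadable because the two values rest on the limit of < 0.024 ug/mL in this assay, at which 1 of the 2 values shown sits, and (the limit of < 0.027 ug/mL in this assay, at which 1 of the 2 values shown sits), so no measured step gives a size to lean on.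

Compound 3 `CNc1cc(CN2C(=O)N(c3ccc(SC(F)(F)F)cc3)C(=O)C2(C)C)ccn1` differs from compound 2 by hydrogen in place of 4-methoxyphenyl on a saturated chain carbon bound to a nitrogen on an aromatic ring. The 4-methoxyphenyl that leaves makes up most of the (4-methoxybenzyl)amino group, and what remains is methylamino. With no readable step among the measured compounds, the expectation rests on the size of what is removed alone. Compound 3 is expected to rise in this assay by an at least 18-fold higher number from compound 2 to compound 3 (1.26 log units; beyond the scatter). Compound 3 is therefore estimated at 0.5 ug/mL, with a range from 0.03 ug/mL to 5 ug/mL.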

Compound 3, solubility: 0.075 ug/mL
Estimate against measurement, compound 3: 6.7-fold (0.82 log units) above; measured number inside the range.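

In this assay compound 3 is the first of the compounds shown to give a number and not a limit, so changes at this position now have a step with a floor on its size. Cutting the (4-methoxybenzyl)amino group back to methylamino gives an at least 2.7-fold higher number from compound 2 to compound 3 (0.44 log units; beyond the scatter), and methylamino in place of piperazin-1-yl on an aromatic carbon gives an at least 3.1-fold higher number from compound 1 to compound 3 (0.49 log units; beyond the scatter). The step from compound 1 to compound 2 still cannot be read, and the two new steps fix only a floor, as each starts from a limit.

On these data alone, how far either step truly runs stays open. A plain amino group or a longer chain such as ethylamino at this place could show whether the number in this assay keeps moving as this group shrinks or grows.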